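The source may report more compounds than this note shows. Statements on the series, on what has been measured and on what is new or still open speak of the compounds shown alone.

In an ADME assay on RAW264.7 cells (Mus musculus) for cytotoxicity, read by MTT assay, with a stated time of 24 h, in the absence of a further agent (a higher number here means a weaker inhibitor, a lower number a stronger inhibitor), compound 1 `COc1ccc(C(O)C2OC(=O)c3c(OC)cc(OC)cc32)cc1` gives > 40000 nM, which is a limit of the assay and not a number. Compound 2 `COCCOc1ccc(C(O)C2OC(=O)c3c(OC)cc(OC)cc32)cc1` gives > 40000 nM, which is also a limit. The two therefore stand together, as the limit of > 40000 nM in this assay, at which 2 of the 2 values shown sit, shows, and compound 2 has no exact value. Compound 3 `COc1cc(OC)c2c(c1)C(C(O)c1ccc(OCCOc3ccccc3)cc1)OC2=O` differs from compound 2 by phenyl in place of methyl on an oxygen on a saturated carbon, or 2-phenoxyethyl for 2-methoxyethyl. Within the data shown here, the only measured step that bears on this change is a step that the two limits leave unreadable from compound 1 to compound 2, and it gives no size to carry over. Little change is therefore expected in this assay, with any shift more likely towards a lower number. The expected change is an at least 1.1-fold lower number from compound 2 to compound 3 (0.05 log units; that floor lies within the scatter). For compound 3 the estimated value is 35000 nM, with an expected range of 12000 nM to 60000 nM.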

Compound 3, half-maximal inhibitory concentration: > 40000 nM
Compound 3 ended at the assay's limit; the forecaster's own chance of this, stated with the estimate: 65%; at least 1.1-fold (0.05 log units) between middle value and limit.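

In this assay, compound 3 sits at a limit of the assay, as compound 1 and compound 2 do, so no step among these compounds can be read: the limit of > 40000 nM in this assay, at which 3 of the 3 values shown sit. What the compounds shown leave open is whether methoxy to phenoxy changes the read-out at all.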